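The compounds below may be only part of what the source reports. "The series", "measured", "known", "first", "only" and "open" are said of these compounds alone.

Of the compounds shown here, two have been measured in an assay on membranes from HEK293 cells for displacement of a labelled ligand from adenosine receptor A2b (Homo sapiens), read by scintillation counting, with a stated time of 30 min; a higher number here means a weaker inhibitor, a lower number a stronger inhibitor. Compound 1 `CC1=C(C(=O)OCc2ccccc2)C(c2cccs2)NC(=O)N1` gives 1920 nM. Compound 2 `CC1=C(C(=O)OC2CCC2)C(c2ccoc2)NC(=O)N1` gives 307 nM, the lower of the two numbers, and the gap up to compound 1 is beyond the scatter; since these two compounds differ in more than one place, only their values can be set side by side. Compound 3 `CC1=C(C(=O)OC2CCC2)C(c2cccs2)NC(=O)N1` is compound 2 with thiophen-2-yl in place of furan-3-yl on a saturated ring carbon. Among the compounds with values here, no measured pair isolates this single change. The step of a 1.6-fold higher number from compound 2 to compound 3 (0.21 log units; within the scatter) is expected to be modest, towards a weaker inhibitor, and not clearly beyond the scatter. For compound 3 the estimate is 500 nM, with a range from 200 nM to 1300 nM.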

Compound 3, inhibition constant: 1090 nM
The estimate for compound 3 lay 2.2-fold (0.34 log units) below the measured number; measured number inside the range.
By their numbers in this assay, from the lowest: compound 2; then compounds 3 and 1 (each within the scatter of the next).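

On a saturated ring carbon of the shared core, thiophen-2-yl in place of furan-3-yl gives a 3.6-fold higher number from compound 2 to compound 3 (0.55 log units; beyond the scatter) in this assay and thus shows that this position distinguishes between two five-membered aromatic rings of equal heavy-atom count. With thiophen-2-yl in place, cyclobutyl in place of benzyl on the oxygen next to a carbonyl group gives a 1.8-fold lower number from compound 1 to compound 3 (0.25 log units; within the scatter) and does not separate those two groups. Nothing measured here explains the step between the two rings. The change alters both the ring hetero atom and its point of attachment, and these compounds leave open which of the two matters. Furan-2-yl or thiophen-3-yl at this position could separate them.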